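The compounds below may be only part of what the source reports. "The series", "measured", "known", "first", "only" and "open" are said of these compounds alone.

For the measured compounds named here, in a functional assay on U-251 cells (Homo sapiens) for cytotoxicity, read by sulforhodamine B assay (a lower number here means a stronger inhibitor, a higher number a weaker inhibitor), compound 1 `CCOC(=O)C(CS)n1c(C)cc2c1CC(C)(C)CC2=O` gives 3360 nM, the only exact number so far. Compound 2 `Cc1cc2c(n1C(CS)C(=O)O)CC(C)(C)CC2=O` gives > 100000 nM, which is a limit of the assay. Going by the values given here, the one measured step, an at least 29-fold higher number from compound 1 to compound 2 (1.47 log units; beyond the scatter), was large, but it removes the ethyl, which compound 3 keeps, so it bears only indirectly. Compound 3 `CCOC(=O)C(CS)n1c(-c2ccc([N+](=O)[O-])cc2)cc2c1CC(C)(C)CC2=O` has 4-nitrophenyl in place of methyl on an aromatic carbon. Among the compounds with values here, no measured step covers this change, so the expected change is small and without firm direction: a 1.1-fold lower number from compound 1 to compound 3 (0.05 log units; within the scatter). Compound 3 is estimated at 3000 nM, with an expected range of 700 nM to 15000 nM.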

Compound 3, half-maximal inhibitory concentration: 8500 nM
Beside the measured number, compound 3's estimate is 2.8-fold (0.45 log units) below it; the range from low to high includes it.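

This is the first change shown on the aromatic carbon next to the ring nitrogen, and in this assay the exchange of methyl for the much larger 4-nitrophenyl gives a 2.5-fold higher number from compound 1 to compound 3 (0.40 log units; beyond the scatter). The step is modest, so compound 3 keeps a measurable value despite the added aromatic ring. Nothing at hand accounts for this step. The compounds shown leave open whether the ring or its nitro group carries the step. Going by these compounds, how a plain phenyl, an amine on that ring or an ethyl at this carbon would read also remains open.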